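Swapping the aryl group on a weakly inhibiting core

The source may report more compounds than this note shows. Statements on the series, on what has been measured and on what is new or still open speak of the compounds shown alone.

Compound 1 `Cc1ccc(NC2=CC(=O)c3c(nc4n3[C@H]3OC[C@@H](O)[C@H]3OC4)C2=O)cc1` carries a (4-methylphenyl)amino group on a double-bonded ring carbon. In a functional assay on ECa-109 cells for inhibition, with ECa-109 cell line (Homo sapiens) as the target, read by sulforhodamine B assay (on this read-out higher numbers stand for weaker inhibition and lower numbers for stronger inhibition), compound 1 gives only a limit, > 4000 nM, so no number is known for it. Its two relatives sit at limits as well. Compound 2 `O=C1C(N2CCCC2)=CC(=O)c2c1nc1n2[C@H]2OC[C@@H](O)[C@H]2OC1` gives a limit of > 16000 nM in this assay. Compound 3 `O=C1C(N2CCCCC2)=CC(=O)c2c1nc1n2[C@H]2OC[C@@H](O)[C@H]2OC1` gives a limit of > 8000 nM in this assay. The steps a step that the two limits leave unreadable from compound 1 to compound 2, a step that the two limits leave unreadable from compound 1 to compound 3 and a step that the two limits leave unreadable from compound 2 to compound 3 therefore cannot be read. Compound 4 `CCOc1ccccc1NC1=CC(=O)c2c(nc3n2[C@H]2OC[C@@H](O)[C@H]2OC3)C1=O` differs from compound 1 by a single change: 2-ethoxyphenyl in place of 4-methylphenyl on an amine nitrogen. Among the compounds with values here, none of the measured steps touches the amine nitrogen, so no size or direction beyond the scatter can be foreseen. Compound 4 is expected at 8000 nM, within a range from 2000 nM to 30000 nM, which means an estimated step that the limit leaves unreadable from compound 1 to compound 4.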

Compound 4, half-maximal inhibitory concentration: 4320 nM
Compound 4: the middle estimate sits 1.9-fold (0.27 log units) above what was measured; the measured number falls inside the stated range.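

Within the data shown here, compound 1 gives only a limit, > 4000 nM, so no step from it to compound 4 can be read. The compounds shown leave open whether 2-ethoxyphenyl in place of 4-methylphenyl changes inhibition at all.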